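Cytotoxicity of a sugar-modified nucleoside pair

A few compounds are considered here, and "the series" means these few. Any claim that something is new, unique, unknown or untested is made for them only; others in the source may bear on it.

The account concerns three compounds sharing one core. Compound 1 `Cc1cn([C@@H]2O[C@H](CO[Si](C)(C)C(C)(C)C)[C@@]3(OS(=O)(=O)C=C3N)[C@H]2O[Si](C)(C)C(C)(C)C)c(=O)n(CCCN(CC(=O)O)CC(=O)O)c1=O` carries a 3-(bis(carboxymethyl)amino)propyl group on the aromatic nitrogen of its base. In an ADME assay on MT4 cells (Homo sapiens) for inhibition (a higher number here means that more compound is tolerated, a lower number that less compound is tolerated), compound 1 gives 123000 nM, the highest of the two numbers recorded so far. Compound 2 `Cc1cn([C@@H]2O[C@H](CO[Si](C)(C)C(C)(C)C)[C@@]3(OS(=O)(=O)C=C3N)[C@H]2O[Si](C)(C)C(C)(C)C)c(=O)n(/C=C/CO)c1=O`, in which that group is replaced by 3-hydroxyprop-1-en-1-yl, gives 4000 nM in this assay, so that the step of a 31-fold lower number from compound 1 to compound 2 (1.49 log units; beyond the scatter) is large and well beyond the scatter.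

Compound 3 `Cc1cn([C@@H]2O[C@H](CO[Si](C)(C)C(C)(C)C)[C@@]3(OS(=O)(=O)C=C3N)[C@H]2O[Si](C)(C)C(C)(C)C)c(=O)n(/C=C\CO)c1=O` has not yet been measured. It differs from compound 1 in the following way: 3-hydroxyprop-1-en-1-yl in place of 3-(bis(carboxymethyl)amino)propyl on an aromatic nitrogen. Compound 3 therefore bears the same 3-hydroxyprop-1-en-1-yl group as compound 2, differing from it only in the geometry of the one double bond outside the aromatic rings. Among the measured compounds shown here, the step from compound 1 to compound 2 is the only measured step that bears on this change, and it was large and downward. A comparable downward step is therefore expected in this assay for compound 3, namely a 31-fold lower number from compound 1 to compound 3 (1.49 log units; beyond the scatter). Compound 3 is accordingly estimated at 4000 nM in this assay, with a range from 1300 nM to 12000 nM.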

Compound 3, half-maximal cytotoxic concentration: 36000 nM
For compound 3 the middle estimate is 9.0-fold (0.95 log units) below the measured one; measured number outside the range, above it.
By their numbers in this assay, from the lowest: compound 2; then compound 3; then compound 1.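

The new value shows that in this assay the exchange of 3-(bis(carboxymethyl)amino)propyl for 3-hydroxyprop-1-en-1-yl on the aromatic nitrogen has no single size: with the double bond drawn Z, the step is a 3.4-fold lower number from compound 1 to compound 3 (0.53 log units; beyond the scatter), which is modest, whereas with the double bond drawn E it is a 31-fold lower number from compound 1 to compound 2 (1.49 log units; beyond the scatter), which is large. At this position, then, the name of the group does not settle the number, and the geometry of its one double bond counts for about as much as the rest of the exchange, with a 9.0-fold higher number from compound 2 to compound 3 (0.95 log units; beyond the scatter). The gap between this pair can be assigned to a single structural difference: the fact that compounds 2 and 3 differ only in the configuration as drawn.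

The compounds shown leave open whether a saturated 3-hydroxypropyl chain on the same nitrogen would read closer to compound 2 or to compound 3, and how a longer chain ending in a hydroxyl would behave. They also leave open which part of the group in compound 1, the tertiary amine or the carboxylic acids, goes with its high number.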